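A few compounds are considered here, and "the series" means these few. Any claim that something is new, unique, unknown or untested is made for them only; others in the source may bear on it.

Compound 1 `COc1ccc([C@@H]2CC(=O)c3c(O)cc(OCc4cn(Cc5ccc(C(F)(F)F)cc5)nn4)cc3O2)cc1O`: 17700 nM
Compound 2 `COc1ccc([C@@H]2CC(=O)c3c(O)cc(OCc4cn(Cc5ccccc5C(F)(F)F)nn4)cc3O2)cc1O`: 12500 nM

Both compounds were tested in a functional assay on RAW264.7 cells (Mus musculus) for inhibition, read by Griess assay, with stated times of 2 h and 24 h; a lower number here means a stronger inhibitor, a higher number a weaker inhibitor. Within the data shown here, compound 2 stands level with compound 1, the only other measured compound, as a 1.4-fold lower number from compound 1 to compound 2 (0.15 log units; within the scatter) shows. Compound 3 `CCCn1cc(COc2cc(O)c3c(c2)O[C@H](c2ccc(OC)c(O)c2)CC3=O)nn1` keeps the shared core but differs from compound 2 in one place: ethyl in place of 2-(trifluoromethyl)phenyl on a saturated chain carbon bound to an aromatic nitrogen. Here ethyl takes the place of 2-(trifluoromethyl)phenyl on a saturated chain carbon bound to an aromatic nitrogen. Among the measured compounds shown here, the one measured step only swaps 4-(trifluoromethyl)phenyl for 2-(trifluoromethyl)phenyl, and its size, a 1.4-fold lower number from compound 1 to compound 2 (0.15 log units; within the scatter), is small. For the measured compounds named here, no measured compound shows what happens when this group is lost altogether, so neither direction can be favoured and no step beyond the scatter is expected. The expected change is a 1.3-fold higher number from compound 2 to compound 3 (0.11 log units; within the scatter), though this estimate is uncertain. Compound 3 is estimated at 16000 nM, within a range of 6000 nM to 45000 nM.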

Compound 3, half-maximal inhibitory concentration: 9670 nM
For compound 3 the middle estimate is 1.7-fold (0.22 log units) above the measured one; measured number inside the range.
By their numbers in this assay, from the lowest: compounds 3, 2 and 1 (each within the scatter of the next).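

Before compound 3, the only comparison at this place exchanged 4-(trifluoromethyl)phenyl for 2-(trifluoromethyl)phenyl, so an aromatic ring was always present. In this assay, ethyl in place of 2-(trifluoromethyl)phenyl gives a 1.3-fold lower number from compound 2 to compound 3 (0.11 log units; within the scatter), and ethyl in place of 4-(trifluoromethyl)phenyl gives a 1.8-fold lower number from compound 1 to compound 3 (0.26 log units; within the scatter), so the ring and its trifluoromethyl group can both be lost without a step beyond the scatter. No available evidence explains why these groups read alike.

On these data alone, it remains open whether any group on this saturated chain carbon can shift the number beyond the scatter. An amine, a carboxylic acid or a longer chain such as octyl could test this, since the groups shown are all carbon-based with no hydrogen-bond donors or acceptors.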